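The source may report more compounds than this note shows. Statements on the series, on what has been measured and on what is new or still open speak of the compounds shown alone.

Compound 1 `COc1ccccc1C1C(C#N)=C(N)N(c2ccc(S(N)(=O)=O)cc2)C2=C1C(=O)CCC2` gives 0% in a functional assay on Ehrlich cells (Mus musculus) for antiproliferative activity, read by trypan blue exclusion, with a stated time of 2 h, tested at 100 ug/mL (on this read-out lower numbers stand for a weaker effect and higher numbers for a stronger effect at the one concentration tested), the lowest of three numbers. Compound 2 `COc1ccc(C2C(C#N)=C(N)N(c3ccc(S(N)(=O)=O)cc3)C3=C2C(=O)CCC3)cc1` gives 100% and compound 3 `Cc1ccoc1C1C(C#N)=C(N)N(c2ccc(S(N)(=O)=O)cc2)C2=C1C(=O)CCC2` gives 45% in this assay. Compound 4 `N#CC1=C(N)N(c2ccc(S(N)(=O)=O)cc2)C2=C(C(=O)CCC2)C1c1cccs1` differs from compound 1 by one change: thiophen-2-yl in place of 2-methoxyphenyl on a saturated ring carbon. Both measured steps from compound 1 bear on this: a number 100 percentage points higher from compound 1 to compound 2 (beyond the scatter) and a number 45 percentage points higher from compound 1 to compound 3 (beyond the scatter). The second step, which also puts a five-membered aromatic ring with one hetero atom on the saturated ring carbon, is the closer guide. A rise beyond the scatter is therefore expected for compound 4, estimated as a number 45 percentage points higher from compound 1 to compound 4 (beyond the scatter). Compound 4 is expected to give 45% in this assay, within a range of 15% to 80%.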

Compound 4, a percentage reported as activity, at one concentration (the size of the read-out at that concentration, not a potency): 100%
For compound 4 the middle estimate is 55 percentage points below the measured one; the whole stated range lies below it.
By their numbers in this assay, from the lowest: compound 1; then compound 3; then compounds 2 and 4 (each within the scatter of the next).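

In this assay, thiophen-2-yl on this saturated ring carbon matches 4-methoxyphenyl, with no change at the digits printed from compound 2 to compound 4 (within the scatter), so a six-membered aromatic ring is not required for the full read-out. A five-membered aromatic ring alone does not settle the number either, since there is a number 55 percentage points higher from compound 3 to compound 4 (beyond the scatter). With a number 100 percentage points higher from compound 1 to compound 4 (beyond the scatter), the 2-methoxyphenyl group of compound 1 remains the weakest of the four groups.

Nothing available explains these differences. From the compounds shown here alone, whether an amine, a carboxylic acid or a longer saturated chain would be tolerated on this carbon remains open.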